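Halogen swap on the aryl urea of the fluorophenoxy-cyclohexyl series

The source may report more compounds than this note shows. Statements on the series, on what has been measured and on what is new or still open speak of the compounds shown alone.

Three compounds share a fluorophenoxy-cyclohexyl urea core and differ only in the aryl group on the urea nitrogen. Compound 1 `O=C(Nc1ccc(I)cc1)N[C@H]1CC[C@H](Oc2ccc(F)cc2)CC1` carries a 4-iodophenyl group, and in a functional assay on CRL2813 cells (Homo sapiens) for cytotoxicity, read by sulforhodamine B assay, with a stated time of 5 days (a lower number here means a stronger inhibitor, a higher number a weaker inhibitor), compound 1 gives 10200 nM. Compound 2 `O=C(Nc1ccc(Br)cc1)N[C@H]1CC[C@H](Oc2ccc(F)cc2)CC1` carries 4-bromophenyl; in this assay compound 2 reaches only the limit of > 20000 nM, which is a limit of the method and not a number. Compound 3 `CSc1ccccc1NC(=O)N[C@H]1CC[C@H](Oc2ccc(F)cc2)CC1` carries 2-(methylsulfanyl)phenyl; in this assay compound 3 likewise sits at the limit of > 20000 nM. Compound 3 thus stands at the weak end of the numbers shown, sharing that position with compound 2 (the limit of > 20000 nM in this assay, at which 2 of the 3 values shown sit).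

The step to compound 4 `O=C(Nc1ccc(Cl)cc1)N[C@H]1CC[C@H](Oc2ccc(F)cc2)CC1` is 4-chlorophenyl in place of 2-(methylsulfanyl)phenyl on an amide-type nitrogen. Within the data shown here, the steps that bear on it are an at least 1.9-fold higher number from compound 1 to compound 3 (0.29 log units; that floor lies within the scatter) and an at least 1.9-fold higher number from compound 1 to compound 2 (0.29 log units; that floor lies within the scatter); the direct comparison a step that the two limits leave unreadable from compound 2 to compound 3 gives no readable size. Exchange of one para-halogen for another, iodo to bromo, already moved the value to the limit, and the bromo and methylsulfanyl analogues are both at that limit, so no step beyond the scatter is expected from compound 3 to compound 4 in this assay, with a fair chance of another limit.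

The estimate for compound 4 is 20000 nM, within 7000 nM to 45000 nM, which corresponds to an expected step of a number no higher from compound 3 to compound 4 (the limit leaves the size open).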

Compound 4, half-maximal inhibitory concentration: > 20000 nM
Compound 4: a limit, no number; the forecaster's own chance of this, stated with the estimate: 60%; the middle value sits exactly at the limit.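

In this assay compound 4 also sits at a limit of the method, > 20000 nM, and not at a number. The exchange of iodo for chloro gives an at least 1.9-fold higher number from compound 1 to compound 4 (0.29 log units; that floor lies within the scatter), so the bromo result no longer stands alone: of the three 4-halophenyl ureas shown, only the 4-iodophenyl group gives a number, and with that floor inside the scatter no order among the three is established. The steps among compound 2, compound 3 and compound 4 cannot be read, so neither the exchange of 2-(methylsulfanyl)phenyl for 4-chlorophenyl nor that of bromo for chloro has a readable size, and the weak end of the series fills further: the limit of > 20000 nM in this assay, at which 3 of the 4 values shown sit.

On these data alone, whether the compounds at the limit differ from one another, and how far beyond it they lie, stays open. Also open, as far as these compounds go, is how an amine or a carboxylic acid in place of the halogen on the aryl group of the urea would read in this assay.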